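This account rests on a few compounds, and the source may have more. Where it says the series, first, only, none or still open, it means among the compounds named here.

Compounds measured so far:
Compound 1 `CCN(CC)CCN/C(=N\c1ccnc2cc(Cl)ccc12)C(C)C` in an ADME assay (liver) for metabolic stability, with Liver microsome (Homo sapiens) as the target, read by LC-MS, using microsomes, tested at 1 uM (on this read-out higher numbers stand for a longer-lived compound and lower numbers for a shorter-lived compound), gives > 1 h.
Compound 2 `C/C(=N/c1ccnc2cc(Cl)ccc12)NC1CCN(C)CC1` in this assay gives > 1 h.
Compound 3 `CCN(CC)CCCCN/C(C)=N\c1ccnc2cc(Cl)ccc12` in this assay gives > 1 h.

Every one of these values is a limit of the assay and not a number. Compound 3 therefore stands at the limit of > 1 h in this assay, at which 3 of the 3 values shown sit, and nothing in the present set separates it from its two companions, since all three sit at the same limit. Among the measured compounds shown here, no step between measured compounds is available here, so no measured change can be drawn on.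

Compound 4 `CCN(CC)CCN/C(C)=N\c1ccnc2cc(Cl)ccc12` has not yet been measured in this assay. It differs from compound 3 in one place: diethylamino in place of 2-(diethylamino)ethyl on a saturated chain carbon, two bonds along the chain from an amine nitrogen. The same difference, cut one bond further out, reads 3-(diethylamino)propyl to (diethylamino)methyl. For the measured compounds named here, with every value so far resting at the limit, there is no direction to read from the set, and the step from compound 3 to compound 4 is expected to be none beyond the scatter; this amounts to an expected step that the limit leaves unreadable from compound 3 to compound 4. Compound 4 is expected to give 1.5 h, with a range from 0.5 h to 4 h, most likely reported again as a limit rather than a number.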

Compound 4, half-life: 0.433 h
Estimate against measurement, compound 4: 3.5-fold (0.54 log units) above; measured number below the stated range.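

Among the compounds shown here, with diethylamino in place of 2-(diethylamino)ethyl on a saturated chain carbon, two bonds along the chain from an amine nitrogen, compound 4 is the only compound of the four that gives a number in this assay, and this change brings an at least 2.3-fold lower number from compound 3 to compound 4 (0.36 log units; beyond the scatter). Two other single changes also end at compound 4: 2-(diethylamino)ethyl in place of 1-methylpiperidin-4-yl on an amine nitrogen brings an at least 2.3-fold lower number from compound 2 to compound 4 (0.36 log units; beyond the scatter), and methyl in place of isopropyl on a carbon with a double bond to nitrogen brings an at least 2.3-fold lower number from compound 1 to compound 4 (0.36 log units; beyond the scatter). The other three compounds remain at a limit and not at a number, so each step gives only a minimum size: the limit of > 1 h in this assay, at which 3 of the 4 values shown sit.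

On these data alone, how far compounds 1, 2 and 3 actually lie from compound 4 stays open. Also open, as far as these compounds go, is whether a chain of intermediate length, or a pyrrolidine or morpholine at the chain end, would stay at the limit or fall to a number as compound 4 does.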